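Moving the Methyl on the Sulfonyl Aryl Ring

A few compounds are considered here, and "the series" means these few. Any claim that something is new, unique, unknown or untested is made for them only; others in the source may bear on it.

Measured compounds:
- compound 1 `COc1ccc(S(=O)(=O)c2ccc(NC(=O)C(C)(O)C(F)(F)F)cc2)cc1`: > 30000 nM
- compound 2 `Cc1ccccc1S(=O)(=O)c1ccc(NC(=O)C(C)(O)C(F)(F)F)cc1`: 5100 nM

In a functional assay (Cavia porcellus) with sulfonylurea receptors; K-ATP channels (Homo sapiens) as the target (on this read-out lower numbers stand for stronger inhibition and higher numbers for weaker inhibition), compound 1 gives only the assay's limit, > 30000 nM. Among the compounds with values here, compound 2 gives 5100 nM, the only real number so far, so it stands alone. Within the data shown here, the single measured step, an at least 5.8-fold lower number from compound 1 to compound 2 (0.76 log units; beyond the scatter), is only a lower bound because one of its two values is the limit of > 30000 nM in this assay, at which 1 of the 2 values shown sits. Compound 3 `Cc1cccc(S(=O)(=O)c2ccc(NC(=O)C(C)(O)C(F)(F)F)cc2)c1` differs from compound 2 by 3-methylphenyl in place of 2-methylphenyl on a sulfonyl sulfur. Among the measured compounds shown here, no measured step shifts a methyl from one ring position to another, so the expected step of a 1.4-fold higher number from compound 2 to compound 3 (0.14 log units; within the scatter) is within the scatter. Compound 3 is estimated at 7000 nM, between 2500 nM and 25000 nM.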

Compound 3, half-maximal inhibitory concentration: 2200 nM
The estimate for compound 3 lay 3.2-fold (0.50 log units) above the measured number; the measured number lies below the stated range.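

Shifting the methyl alone, with the same atoms joined differently, gives a 2.3-fold lower number from compound 2 to compound 3 (0.37 log units; beyond the scatter), so the place of this one methyl on the ring matters by itself. Putting 3-methylphenyl in place of 4-methoxyphenyl gives an at least 13-fold lower number from compound 1 to compound 3 (1.13 log units; beyond the scatter). That step is only a lower bound, since compound 1 carries a limit and not a number: the limit of > 30000 nM in this assay, at which 1 of the 3 values shown sits.

From the compounds shown here alone, it remains open whether an ethyl group, a chlorine or an amine in the methyl's place would lower the number further. Also open, going by these compounds, is whether the methoxy group itself or its place on the ring accounts for the weak result of compound 1.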